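From a Branched Alkyl to an Oxetane on the Amide

A few compounds are considered here, and "the series" means these few. Any claim that something is new, unique, unknown or untested is made for them only; others in the source may bear on it.

Within the data shown here, compound 3 `C[C@H](NC(=O)c1ccc(C#Cc2cccc(F)c2)cn1)C(C)(C)C` gives 70.8% in a functional assay on HEK293 cells for positive allosteric modulation of metabotropic glutamate receptor 5 (Rattus norvegicus), read by fluorescence and calcium flux (a lower number here means a smaller maximal response, a higher number a larger maximal response), the highest of the three numbers measured so far. Compound 2 `C[C@@H](NC(=O)c1ccc(C#Cc2ncccc2F)cn1)C(C)(C)O` gives 60.6% and compound 1 `C[C@@H](NC(=O)c1ccc(C#Cc2ccccc2F)cn1)C(C)(C)O` gives 60%; both lie beyond the scatter below compound 3. Among the measured compounds shown here, the only step measured between compounds that differ in one place, a number 0.6 percentage points higher from compound 1 to compound 2 (within the scatter), concerns the group on the triple-bonded carbon and stays within the scatter. Compound 4 `CC1(CCNC(=O)c2ccc(C#Cc3cccc(F)c3)cn2)COC1` differs from compound 3 at the amide-type nitrogen: 2-(3-methyloxetan-3-yl)ethyl in place of 1,2,2-trimethylpropyl on an amide-type nitrogen. For the measured compounds named here, no measured step touches this position; compounds 1 and 2 carry a different group there than compound 3, but they also differ at the fluorinated ring, so their values do not isolate the amide side. The step to compound 4 therefore rests on the structural change alone, and a moderate decrease in this assay is expected, a number 8.8 percentage points lower from compound 3 to compound 4 (within the scatter). For compound 4 the maximal response is estimated at 62%, between 45% and 80%.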

Compound 4, largest response reached (reported as efficacy), in percent of the reference or control that the assay uses: 65.7%
The estimate for compound 4 lay 3.7 percentage points below the measured number; the measured number falls inside the stated range.
By their numbers in this assay, from the lowest: compounds 1, 2, 4 and 3 (each within the scatter of the next, the first and the last beyond it).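

In this assay, among these compounds, the first measured step at the amide-type nitrogen reads a number 5.1 percentage points lower from compound 3 to compound 4 (within the scatter). The position thus tolerates 2-(3-methyloxetan-3-yl)ethyl in place of 1,2,2-trimethylpropyl: the exchange brings in a four-membered ring with one oxygen and a hydrogen-bond acceptor and removes the defined stereocentre, yet the maximal response stays within the scatter. No measurement bearing on the cause of this result is available.

On these data alone, it remains open how a primary amine, a carboxylic acid or a longer chain on this amide-type nitrogen would read in this assay. Also open, as far as these compounds go, is whether 2-(3-methyloxetan-3-yl)ethyl would give a comparable result alongside the fluorinated rings of compound 1 and compound 2.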